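The source may report more compounds than this note shows. Statements on the series, on what has been measured and on what is new or still open speak of the compounds shown alone.

Measured in a functional assay on NTUB1 cells (Homo sapiens) for cytotoxicity, read by MTT assay, with a stated time of 72 h; a higher number here means a weaker inhibitor, a lower number a stronger inhibitor:
- Compound 1 `CCOC(=O)c1ccc(/C=C/C(=O)c2cc(OC)ccc2OC)cc1`: 4490 nM
- Compound 2 `COc1ccc(OC)c(C(=O)/C=C/c2ccc(C(=O)OCc3ccccc3)cc2)c1`: 13300 nM

Compound 2 stands highest of these two. Compound 3 `CNC(=O)c1ccc(/C=C/C(=O)c2cc(OC)ccc2OC)cc1` departs from it at one place, with methylamino in place of benzyloxy on a carbonyl carbon. Among the compounds with values here, the one measured step, a 3.0-fold higher number from compound 1 to compound 2 (0.47 log units; beyond the scatter), is modest and exchanges phenyl in place of methyl, so it is only a loose guide to this change. With so little to go on, a shift toward the lower number that stays within the scatter is expected in this assay, namely a 1.7-fold lower number from compound 2 to compound 3 (0.22 log units; within the scatter). For compound 3 the estimated value is 8000 nM, with an expected range from 2500 nM to 26000 nM.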

Compound 3, half-maximal inhibitory concentration: 2200 nM
Compound 3: the middle estimate sits 3.6-fold (0.56 log units) above what was measured; measured number outside the range, below it.
By their numbers in this assay, from the lowest: compound 3; then compound 1; then compound 2.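

In this assay, methylamino on the carbonyl carbon gives a 6.0-fold lower number from compound 2 to compound 3 (0.78 log units; beyond the scatter) in place of benzyloxy and a 2.0-fold lower number from compound 1 to compound 3 (0.31 log units; beyond the scatter) in place of ethoxy. Within the data shown here, the earlier pair compared only two oxygen-linked groups, whereas compound 3 shows that a nitrogen-linked group at this place takes the number below both of them. Nothing available explains this shift.

The compounds shown leave open how a carboxylic acid, a primary amide or a dimethylamide would compare at this carbonyl carbon. They also leave open whether a longer chain on the amide nitrogen would keep the lower number.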